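This account rests on a few compounds, and the source may have more. Where it says the series, first, only, none or still open, it means among the compounds named here.

Compound 1 `O=C(O)CCCCCCCCCCn1nc(-c2ccccc2)c(-c2ccccc2)c1-c1ccccc1` carries the shared core on a long saturated chain ending in a carboxylic acid. In a functional assay for inhibition, with Homo sapiens as the target (on this read-out lower numbers stand for stronger inhibition and higher numbers for weaker inhibition), compound 1 gives 18600 nM, and this is the only numerical result among the three measured compounds. Compound 2 `O=C(O)CCCCCCCCn1nc(-c2ccccc2)c(Cc2ccccc2)c1-c1ccccc1` reaches only the limit > 68000 nM in this assay. Compound 3 `O=C(O)CCCCCCCCn1cc(-c2ccccc2)cn1` likewise reaches only the limit > 105000 nM in this assay. Within the data shown here, no pair of these measured compounds differs in a single place, so no measured step can be drawn between them.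

Compound 4 `N#CCCCCCCCCn1nc(-c2ccccc2)c(-c2ccccc2)c1-c1ccccc1` has not yet been measured. It differs from compound 1 by cyano in place of 2-carboxyethyl on a saturated chain carbon, eight bonds along the chain from an aromatic nitrogen. The carboxylic acid and its two chain carbons are lost, and a nitrile takes their place on a shorter chain. Among the measured compounds shown here, with no measured step of this kind to lean on, only a modest expectation can be formed. Compound 4 is expected to inhibit less strongly than compound 1, a step estimated at a 2.2-fold higher number from compound 1 to compound 4 (0.33 log units; beyond the scatter) in this assay. Compound 4 is therefore estimated at 40000 nM, within a range from 12000 nM to 130000 nM.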

Compound 4, half-maximal inhibitory concentration: > 72000 nM
Compound 4: only a limit was reported (the forecaster's own chance of this, stated with the estimate: 40%); middle value at least 1.8-fold (0.25 log units) from the limit.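

Putting cyano in place of 2-carboxyethyl on a saturated chain carbon, eight bonds along the chain from an aromatic nitrogen, gives an at least 3.8-fold higher number from compound 1 to compound 4 (0.58 log units; beyond the scatter). Among these compounds, this is the first comparison here between compounds that differ in one place, and it shows that, on the shared core, the numerical result of compound 1 does not survive this change at the chain end. In this assay compound 4 gives only a limit, so the step has a lower bound and no upper one: the limit of > 72000 nM in this assay, at which 1 of the 4 values shown sits.

The change removes the carboxylic acid and shortens the chain in the same step, so the compounds shown do not tell which of the two matters. A carboxylic acid on the shorter chain, a nitrile on the longer chain, or an amide at the chain end would each bear on that question.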